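Squalene synthase inhibitors: removing the amide from compound 3

A few compounds are considered here, and "the series" means these few. Any claim that something is new, unique, unknown or untested is made for them only; others in the source may bear on it.

Measured so far:
compound 1 `CC(C)NCC(O)COc1ccccc1Cc1ccccc1` 8800 nM
compound 2 `C=CCc1ccccc1OCCCNC(C)C` 56 nM
compound 3 `CCC(=O)Nc1ccc(OCCCNC(C)C)c(Cc2ccccc2)c1` 0.6 nM

In an assay for inhibition of squalene synthase (Rattus norvegicus), using microsomes (on this read-out higher numbers stand for weaker inhibition and lower numbers for stronger inhibition), compound 3 has the lowest number of the three, well beyond the scatter from compound 2 and further still from compound 1. Compound 4 `CC(C)NCCCOc1ccccc1Cc1ccccc1` has not been measured; it differs from compound 3 by hydrogen in place of propanoylamino on an aromatic carbon. Among the compounds with values here, no step between measured compounds isolates this change. Compound 2, which also lacks an amide, gives 56 nM, whereas compound 3 gives 0.6 nM, so a sizeable rise in number is expected for compound 4. The expected step is a 33-fold higher number from compound 3 to compound 4 (1.52 log units; beyond the scatter), taking compound 4 to an estimated 20 nM (range 3 nM to 150 nM).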

Compound 4, half-maximal inhibitory concentration: 12 nM
The estimate for compound 4 lay 1.7-fold (0.22 log units) above the measured number; the measured number falls inside the stated range.
By their numbers in this assay, from the lowest: compound 3; then compound 4; then compound 2; then compound 1.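

Within the data shown here, replacing propanoylamino with hydrogen on the aromatic carbon para to the 3-(isopropylamino)propoxy group gives a 20-fold higher number from compound 3 to compound 4 (1.30 log units; beyond the scatter) and isolates this position for the first time, showing that the amide carries much of the strength of compound 3. Even without the amide, the shared core keeps a low number: phenyl in place of vinyl gives a 4.7-fold lower number from compound 2 to compound 4 (0.67 log units; beyond the scatter) and hydrogen in place of hydroxy gives a 730-fold lower number from compound 1 to compound 4 (2.87 log units; beyond the scatter) on the chain.

From the compounds shown here alone, whether a simple amino group, an acetylamino group or a methoxy group on this carbon would recover the low number stays open. Nothing at hand accounts for these steps.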